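From a naphthyl group to a benzothiazolyl group

This account rests on a few compounds, and the source may have more. Where it says the series, first, only, none or still open, it means among the compounds named here.

Compound 1, `CN1CCN(c2ccc3nc(-c4cccc(-c5ccccc5)c4)c(-c4ccncc4)n3n2)CC1`, gives 450 nM in an assay on Sf9 cells for inhibition of receptor-interacting serine/threonine-protein kinase 3 (Homo sapiens), read by luminescence and 33P incorporation, with a stated time of 30 min, in the presence of a further agent that is not named here; on this read-out higher numbers stand for weaker inhibition and lower numbers for stronger inhibition.
Compound 2, `CN1CCN(c2ccc3nc(-c4cccc5ccccc45)c(-c4ccncc4)n3n2)CC1`, gives 880 nM in this assay.
Compound 3, `CN1CCN(c2ccc3nc(-c4ccc(-c5ccccc5)cc4)c(-c4ccncc4)n3n2)CC1`, reaches only the limit of this assay, > 10000 nM.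

Three compounds share one core and differ only in the aromatic group on the five-membered ring. Compound 2 has the higher of the two numbers that were actually measured, and compound 1 is the nearest to it, but the gap between compound 1 and compound 2 lies within the usual scatter of this assay, so the two cannot be ranked against each other. Compound 3 sits at the limit of this assay, (the limit of > 10000 nM in this assay, at which 1 of the 3 values shown sits), and gives no number at all.

Compound 4, `CN1CCN(c2ccc3nc(-c4ccc5ncsc5c4)c(-c4ccncc4)n3n2)CC1`, has not been measured. It differs from compound 2 in one place: 1,3-benzothiazol-6-yl in place of naphthalen-1-yl on an aromatic carbon. Compound 4 is expected to give a weaker number than compound 2 in this assay, with the expected step from compound 2 to compound 4 being a 2.8-fold higher number from compound 2 to compound 4 (0.45 log units; beyond the scatter), somewhat beyond the scatter. The estimate for compound 4 is 2500 nM, with a range from 600 nM to 10000 nM.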

Compound 4, half-maximal inhibitory concentration: > 10000 nM
Compound 4: only a limit was reported (the forecaster's own chance of this, stated with the estimate: 25%); at least 4.0-fold (0.60 log units) between middle value and limit.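

Compound 4 gives only a limit of this assay, > 10000 nM, and not a number. This is the first change in a single place shown for the aromatic group on the five-membered ring, and putting 1,3-benzothiazol-6-yl in place of naphthalen-1-yl gives an at least 11-fold higher number from compound 2 to compound 4 (1.05 log units; beyond the scatter), which shows that this position does not treat all two-ring aromatic groups alike. The step is a lower bound on the change and not its full size, and the limit it rests on is a common one in this small set: the limit of > 10000 nM in this assay, at which 2 of the 4 values shown sit.

The swap changes the ring atoms and the point of attachment together, so the step cannot say which of the two matters, and a naphthalen-2-yl group, which keeps the carbon-only rings but moves the attachment, is the kind of group that would separate them. Also open is how this position responds to groups of a different type, such as an amine or a carboxylic acid on the naphthalen-1-yl ring, and nothing shown here explains why activity falls.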